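Swapping an aryl group on a weak antiproliferative scaffold

A few compounds are considered here, and "the series" means these few. Any claim that something is new, unique, unknown or untested is made for them only; others in the source may bear on it.

Compound 1 `CCOc1ncccc1-c1c(C)nn(-c2nc(-c3ccc(Cl)c(Cl)c3)c(SC(C)C)s2)c1C(=O)O` was tested in a functional assay on BJAB cells (Homo sapiens) for antiproliferative activity, with a stated time of 4 days (on this read-out lower numbers stand for an effect already at smaller amounts and higher numbers for an effect only at larger amounts of compound), where compound 1 gives 11000 nM. Going by the values given here, this is the only number in the set, so compound 1 stands as the sole reference point; compound 2 `Cc1c(-c2cc(Cl)cc(Cl)c2)c(C(=O)O)nn1-c1nc(-c2ccncc2)c(SC(C)C)s1` was tested in the same way and is recorded as "not active" (no number reported), without a number to compare. Compound 3 `Cc1nn(-c2nc(-c3ccc(Cl)c(Cl)c3)c(SC(C)C)s2)c(C(=O)O)c1-c1cccc(F)c1` differs from compound 1 in one place: 3-fluorophenyl in place of 2-ethoxypyridin-3-yl on an aromatic carbon. The change sits on the shared core, on an aromatic carbon of a five-membered aromatic ring with 2 nitrogen, next to the ring atom that bears a carboxy group and next to the ring atom that bears a methyl group. Among the compounds with values here, no pair of measured compounds shows what such a swap does, so the direction is open. Given that compound 1 gives only 11000 nM, the expected step of a 1.4-fold lower number from compound 1 to compound 3 (0.14 log units; within the scatter) from compound 1 to compound 3 is small and may lie within the scatter. Compound 3 is therefore estimated at 8000 nM, within a range from 2000 nM to 30000 nM.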

Compound 3, half-maximal effective concentration: 900 nM
The estimate for compound 3 lay 8.9-fold (0.95 log units) above the measured number; the whole stated range lies above it.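

In this assay, replacing 2-ethoxypyridin-3-yl with 3-fluorophenyl on this aromatic carbon of the shared core gives a 12-fold lower number from compound 1 to compound 3 (1.09 log units; beyond the scatter), so the group at this place clearly affects the read-out, and the weak number of compound 1 does not hold for every aryl group here. The swap changes several things at once: the entering group has fewer heavy atoms, its ring is carbon only, and it carries a fluorine but no hydrogen-bond acceptors, whereas the leaving group has two. Nothing measured here explains why the number falls, so the step remains an observation without a known cause.

This single pair cannot separate the loss of the ring nitrogen, the loss of the ethoxy group and the gain of the fluorine, and any of these could account for some or all of the step. It also leaves open how an unsubstituted phenyl, or a phenyl bearing a chlorine, a methoxy group or an amine at the same place, would compare with the 3-fluorophenyl of compound 3.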